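Adding One Methyl to Compound 2

A few compounds are considered here, and "the series" means these few. Any claim that something is new, unique, unknown or untested is made for them only; others in the source may bear on it.

Of the compounds shown here, two have been measured in a functional assay on MCF7 cells (Homo sapiens) for cytotoxicity, read by MTT assay, with a stated time of 24 h, tested at 20 uM; on this read-out higher numbers stand for a weaker effect at the one concentration tested and lower numbers for a stronger effect. Compound 1 `Cc1nc2c(Br)c(Br)c(Br)c(Br)c2n1CC#N` gives 36%, while compound 2 `N#CCCn1cnc2c(Br)c(Br)c(Br)c(Br)c21` gives 72%, the higher of the two numbers, with a gap that lies beyond the usual scatter. Compound 3 `Cc1nc2c(Br)c(Br)c(Br)c(Br)c2n1CCC#N` has not been measured yet. It differs from compound 2 in one place: methyl in place of hydrogen on an aromatic carbon. Going by the values given here, no pair of measured compounds shows this same change on its own, so its effect here is unknown. Compound 1 does carry the same methyl, yet it also has a shorter chain, so two things differ at once and it is only a loose hint. A moderate step toward a stronger effect is expected, of about a number 17 percentage points lower from compound 2 to compound 3 (beyond the scatter), partly because compound 1 gives 36%. Compound 3 is therefore estimated at 55%, within a range of 35% to 75%.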

Compound 3, a percentage reported as activity, at one concentration (the size of the read-out at that concentration, not a potency): 74%
For compound 3 the middle estimate is 19 percentage points below the measured one; the measured number falls inside the stated range.
By their numbers in this assay, from the lowest: compound 1; then compounds 2 and 3 (each within the scatter of the next).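

Methyl in place of hydrogen on an aromatic carbon, between two ring nitrogen atoms, gives a number 2 percentage points higher from compound 2 to compound 3 (within the scatter) in this assay and so, with the 2-cyanoethyl group present, compounds 2 and 3 cannot be told apart. With that methyl present in both compounds, cyanomethyl in place of cyano on a saturated chain carbon bound to an aromatic nitrogen gives a number 38 percentage points higher from compound 1 to compound 3 (beyond the scatter) and this is a large step. Among these compounds, the clear difference therefore follows the chain on the ring nitrogen and not the methyl.

Still open, from the compounds shown here alone, is whether the methyl would count for as little alongside the cyanomethyl group of compound 1, and how an amine or a carboxylic acid at the end of the chain would read. Nothing available here explains the size of either step.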